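Imidazole for Furan on the Diarylamine Series

The source may report more compounds than this note shows. Statements on the series, on what has been measured and on what is new or still open speak of the compounds shown alone.

The series rests on a diarylamine core carrying a nitrile. For the measured compounds named here, compound 1 `N#Cc1ccc(N2CCCc3c(-c4cccnc4)cccc32)cc1C(F)(F)F` is the only member with a number in an ADME assay on L02 cells (Homo sapiens) for antiproliferative activity, read by CCK-8 assay, with a stated time of 6 days (on this read-out higher numbers stand for weaker inhibition and lower numbers for stronger inhibition), where compound 1 gives 10500 nM. Compound 2 `CCN(c1ccc(C#N)c(Cl)c1)c1cc(-c2ccco2)ccc1C` has no result in this assay, where the entry for compound 2 reads "not determined" (no result reported). Compound 3 `CCN(c1cccc(-n2ccnc2)c1)c1ccc(C#N)c(C(F)(F)F)c1` likewise has none; in this assay compound 3 reads "not determined" (no result reported). So compound 2 cannot be placed against any neighbour on the numbers at hand; the one measured compound, compound 1, serves only as a rough anchor for the range this read-out covers. Compound 4 `CCN(c1ccc(C#N)c(Cl)c1)c1cc(-n2ccnc2)ccc1C` is to be measured in this assay. It differs from compound 2 by one change: 1H-imidazol-1-yl in place of furan-2-yl on an aromatic carbon. Going by the values given here, with no measured pair of this kind, the account expects this change to move the half-maximal inhibitory concentration by no more than the usual scatter, with no direction claimed. Taking compound 1 as the anchor of the read-out, compound 4 is estimated at 10000 nM, with a range from 3000 nM to 40000 nM.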

Compound 4, half-maximal inhibitory concentration: 15000 nM
Compound 4: middle estimate off by 1.5-fold (0.18 log units), on the low side, and the stated range covers the measured number.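

The result for compound 4 yields no readable step, as its one-place neighbour, compound 2, carries no number in this assay. From the compounds shown here alone, the effect of 1H-imidazol-1-yl in place of furan-2-yl on this read-out stays open. No evidence at hand bears on the value of compound 4.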